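Working notes: from compound 2 to compound 4

A few compounds are considered here, and "the series" means these few. Any claim that something is new, unique, unknown or untested is made for them only; others in the source may bear on it.

Measured so far:
Compound 1, `CCCCCCCCN(C)C(=O)Cn1cc(Cc2cnc(O)nc2)c(=O)nc1SCc1ccc(F)cc1`, gives 34% in a functional assay on a cell-free system (plasma, Oryctolagus cuniculus) for inhibition of platelet-activating factor acetylhydrolase (Homo sapiens), tested at 100 nM; a higher number here means more inhibition at the concentration tested (going by the name of the read-out), a lower number less inhibition.
Compound 2, `CCCCCCCCN(C)C(=O)Cn1cc(Cc2cnc(=O)n(CCO)c2)c(=O)nc1SCc1ccc(F)cc1`, gives 36% in this assay.
Compound 3, `CCCCCCCCCCCCN(C)C(=O)Cn1cc(Cc2cnc(=O)n(CCO)c2)c(=O)nc1SCc1ccc(F)cc1`, gives 36% in this assay.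

Compound 2 stands level with compound 3, the two showing no change at the digits printed from compound 2 to compound 3 (within the scatter), and it lies within the scatter of compound 1, which shows a number 2 percentage points higher from compound 1 to compound 2 (within the scatter). All three numbers therefore sit in one narrow band, and nothing in the set is separated from the rest beyond the usual scatter.

Compound 4, `CCCCCCCCN(C)C(=O)Cn1cc(Cc2cnc(=O)n(CC(=O)N3CCNC(=O)C3)c2)c(=O)nc1SCc1ccc(F)cc1`, is not yet measured. It differs from compound 2 by (3-oxopiperazin-1-yl)carbonyl in place of hydroxymethyl on a saturated chain carbon bound to an aromatic nitrogen. Going by the values given here, of the measured steps, only the one from compound 1 to compound 2 touches the same region, the substituent on the aromatic nitrogen, and it moved the number by a number 2 percentage points higher from compound 1 to compound 2 (within the scatter). The chain-lengthening step from compound 2 to compound 3 moved it by no change at the digits printed from compound 2 to compound 3 (within the scatter). Neither step gives a reason to expect a shift beyond the scatter, so compound 4 is expected to show a number 1 percentage points lower from compound 2 to compound 4 (within the scatter). The estimate for compound 4 in this assay is 35%, with a range from 18% to 52%.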

Compound 4, a percentage reported as inhibition, at one concentration (the size of the read-out at that concentration, not a potency): 55%
Beside the measured number, compound 4's estimate is 20 percentage points below it; measured number outside the range, above it.
By their numbers in this assay, from the lowest: compounds 1, 2 and 3 (each within the scatter of the next); then compound 4.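

In this assay, going by these compounds alone, the substituent on the aromatic nitrogen is the first place to give a step beyond the scatter: (3-oxopiperazin-1-yl)carbonyl in place of hydroxymethyl gives a number 19 percentage points higher from compound 2 to compound 4 (beyond the scatter). The earlier steps, a number 2 percentage points higher from compound 1 to compound 2 (within the scatter) and no change at the digits printed from compound 2 to compound 3 (within the scatter), stayed within the scatter, so this saturated chain carbon bound to an aromatic nitrogen is the one place shown where a change separates one compound from the rest, and it accepts the larger ring-bearing group without loss. Nothing available explains the gain.

Open, going by these compounds, is which part of the entering group carries the step, since a simple dimethylamide, a morpholine amide or a carboxylic acid at this place would separate the carbonyl from the ring. Also open, on these data alone, is whether a longer chain on the amide nitrogen would behave differently with this group in place.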